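The source may hold more compounds than are shown below. What is called first, only, known or untested is meant among the compounds shown, and "the series" means these compounds.

Compound 1 `COc1ccc(-n2c(SCC(=O)Nc3nc4ccc(C(F)(F)F)cc4s3)nc3c(c2=O)SCC3)cc1`: 100 nM
Compound 2 `COc1ccc(-n2nc(C(=O)NCC(=O)Nc3nc4ccc(Cl)cc4s3)c3ccccc3c2=O)cc1`: 15 nM

Of the two measured compounds, compound 1 stands at the higher number. In an assay on L cells for inhibition of Protein-serine O-palmitoleoyltransferase porcupine (Mus musculus), read by reporter gene assay, with a stated time of 24 h (a lower number here means that less compound is needed, a higher number that more compound is needed for the effect), compound 1 gives 100 nM, whereas compound 2 gives 15 nM, a gap beyond the usual scatter. Among the compounds with values here, the two measured compounds differ in several places at once, so no single measured step is available to lean on.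

Compound 3 `O=C(CSc1nc2c(c(=O)n1-c1ccc(F)cc1)SCC2)Nc1nc2ccc(C(F)(F)F)cc2s1` has not yet been measured. Relative to compound 1 it carries fluoro in place of methoxy on an aromatic carbon. Within the data shown here, no measured pair shows this exchange, so the expectation rests only on the small size of the change and on the value of compound 1, which is 100 nM. The expected step of a 1.3-fold higher number from compound 1 to compound 3 (0.11 log units; within the scatter) is small, not beyond the scatter, with at most a slight lean toward a higher number. For compound 3 the estimate in this assay is 130 nM, with a range from 50 nM to 350 nM.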

Compound 3, half-maximal effective concentration: 100 nM
Compound 3: the middle estimate sits 1.3-fold (0.11 log units) above what was measured, and the stated range covers the measured number.
By their numbers in this assay, from the lowest: compound 2; then compounds 1 and 3 (each within the scatter of the next).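

Within the data shown here, the exchange of 4-methoxyphenyl to 4-fluorophenyl in this assay gives no change at the digits printed from compound 1 to compound 3 (within the scatter) and is the only single-place step available so far. At this position on the aromatic ring, the methoxy group is therefore not required to hold the number on the core of compound 1, and a single fluoro atom serves as well, with one hydrogen-bond acceptor fewer counted in the group. No measured evidence bears on why the number holds across this exchange.

Going by these compounds, whether this position accepts groups of other kinds stays open: an amine, a carboxylic acid or a longer alkoxy chain here would test how far the tolerance reaches. Also open, on these data alone, is whether the same exchange leaves the number in place on the core of compound 2.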